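Sulfur side chain: carbamoylmethyl to 3-aminopropyl

The source may hold more compounds than are shown below. What is called first, only, known or untested is meant among the compounds shown, and "the series" means these compounds.

Measured in a functional assay on HT cells (Homo sapiens) for antiproliferative activity, read by fluorescence, with a stated time of 72 h (a higher number here means a weaker inhibitor of growth, a lower number a stronger inhibitor of growth), so far:
- compound 1 `CC(C)c1n[nH]c2c(NCc3ccc(-c4ccccn4)cc3)nc(SC(CO)C(C)C)nc12` gives 980 nM
- compound 2 `CC(C)c1n[nH]c2c(NCc3ccc(-c4ccccn4)cc3)nc(SC3CCCC3O)nc12` gives 567 nM
- compound 3 `CC(C)c1n[nH]c2c(NCc3ccc(-c4ccccn4)cc3)nc(SCC(N)=O)nc12` gives 192 nM

Compound 3 has the lowest number of the three, and its steps to both others lie beyond the scatter. The next structure is compound 4 `CC(C)c1n[nH]c2c(NCc3ccc(-c4ccccn4)cc3)nc(SCCCN)nc12` with this change: 2-aminoethyl in place of carbamoyl on a saturated chain carbon bound to a sulfur. In words, 2-aminoethyl replaces carbamoyl on a saturated chain carbon bound to a sulfur. Three measured steps on the same sulfur bear on this: a 5.1-fold lower number from compound 1 to compound 3 (0.71 log units; beyond the scatter) and a 3.0-fold lower number from compound 2 to compound 3 (0.47 log units; beyond the scatter) are modest, while a 1.7-fold lower number from compound 1 to compound 2 (0.24 log units; within the scatter) stays within the scatter. Within the data shown here, no measured compound carries 3-aminopropyl, so the data give no direction, and no step beyond the scatter is expected in this assay. The estimate implies a 1.1-fold lower number from compound 3 to compound 4 (0.03 log units; within the scatter) as the expected step. The expected value for compound 4 is 180 nM with an estimated range from 60 nM to 550 nM in this read-out.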

Compound 4, concentration for 50% growth inhibition: 120 nM
Compound 4: middle estimate off by 1.5-fold (0.18 log units), on the high side; measured number inside the range.
By their numbers in this assay, from the lowest: compounds 4 and 3 (each within the scatter of the next); then compounds 2 and 1 (each within the scatter of the next).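

In this assay, carbamoyl is not required on this sulfur chain: 2-aminoethyl in its place gives a 1.6-fold lower number from compound 3 to compound 4 (0.20 log units; within the scatter). The amine-bearing chain also stands clear of both hydroxyl-bearing chains, with a 4.7-fold lower number from compound 2 to compound 4 (0.67 log units; beyond the scatter) and an 8.2-fold lower number from compound 1 to compound 4 (0.91 log units; beyond the scatter), so the two nitrogen-bearing chains in compounds 3 and 4 both sit below those in compounds 1 and 2. No measured evidence accounts for these steps. Open, going by these compounds, is how a longer aminoalkyl chain, a dimethylamine or a carboxylic acid on the same sulfur chain would read out.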